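The source may report more compounds than this note shows. Statements on the series, on what has been measured and on what is new or still open speak of the compounds shown alone.

Among the measured compounds shown here, compound 3 `O=c1c(Cl)c(CSC(=S)N2CCCC2)oc2ccccc12` sits second highest among the three numbers so far in a functional assay on HeLa cells (Homo sapiens) for antiproliferative activity, read by MTT assay, with a stated time of 72 h; on this read-out higher numbers stand for weaker inhibition and lower numbers for stronger inhibition: compound 3 gives 700 nM, compound 2 `O=c1c(CSC(=S)N2CCCCC2)coc2cc(Cl)ccc12` gives 440 nM, and compound 1 `O=c1c(Cl)c(CSC(=S)N2CCOCC2)oc2ccccc12` gives 4500 nM. For the measured compounds named here, compound 3 and compound 2 lie within the scatter of each other; compound 1 stands apart, and the only single-point step so far, a 6.4-fold lower number from compound 1 to compound 3 (0.81 log units; beyond the scatter), concerns the amine on the thiocarbonyl carbon and not the ring.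

Compound 4 `O=c1cc(CSC(=S)N2CCCC2)oc2ccccc12` is compound 3 with hydrogen in place of chloro on an aromatic carbon, on an aromatic carbon of the six-membered aromatic ring with one oxygen, two atoms from the ring oxygen. Going by the values given here, no measured pair shows the loss of that chloro; compound 2 carries its chloro on the other ring and a different amine, so its value against that of compound 3 bears only loosely on this step. The direction is therefore uncertain, and only a modest shift, if any beyond the scatter, is expected, as a 1.7-fold higher number from compound 3 to compound 4 (0.23 log units; within the scatter) expresses. Compound 4 is estimated at 1200 nM, within a range of 400 nM to 4000 nM.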

Compound 4, half-maximal inhibitory concentration: 23100 nM
Estimate against measurement, compound 4: 19-fold (1.28 log units) below; the measured number lies above the stated range.
By their numbers in this assay, from the lowest: compounds 2 and 3 (each within the scatter of the next); then compound 1; then compound 4.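

At this position, on an aromatic carbon of a six-membered aromatic ring with 1 oxygen, two atoms from the ring oxygen, the chloro proves decisive: hydrogen in its place gives a 33-fold higher number from compound 3 to compound 4 (1.52 log units; beyond the scatter) in this assay. Among the compounds shown here, this is the first measured pair to test this position, and its large step exceeds the modest one for the amine change, a 6.4-fold lower number from compound 1 to compound 3 (0.81 log units; beyond the scatter), so the group here counts for more than that amine swap. Nothing measured alongside these values explains the loss.

Going by these compounds, whether another group at this position, such as bromo, methyl or a nitrile, would keep the number near that of compound 3 stays open. So does whether losing the chloro would cost as much with the morpholin-4-yl amine of compound 1.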